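Ethyl Extension on Two Dioxolane Piperidine and Amine Cores

A few compounds are considered here, and "the series" means these few. Any claim that something is new, unique, unknown or untested is made for them only; others in the source may bear on it.

Compound 1 `C[C@]1(c2ccccc2)OC[C@H]([C@@H]2CCCCN2)O1`: 847 nM
Compound 2 `CCC[C@]1(c2ccccc2)OC[C@H]([C@@H]2CCCCN2)O1`: 69 nM
Compound 3 `C[C@H](N)[C@H]1COC(c2ccccc2)(c2ccccc2)O1`: 607 nM

In a functional assay (brain) for displacement of a labelled ligand, with Rattus norvegicus as the target (a higher number here means a weaker inhibitor, a lower number a stronger inhibitor), compound 1 gives 847 nM, and compound 2 gives 69 nM. The step of a 12-fold lower number from compound 1 to compound 2 (1.09 log units; beyond the scatter) follows from the change (ethyl in place of hydrogen on a saturated chain carbon bound to a saturated ring carbon). Compound 3 gives 607 nM in this assay; the difference between the core of compound 3 and the core of compound 1 is not broken down here. Compound 4 `CCC[C@H](N)[C@H]1COC(c2ccccc2)(c2ccccc2)O1` carries the change (ethyl in place of hydrogen on a saturated chain carbon, two bonds along the chain from an amine nitrogen and a saturated ring carbon). It is the same kind of change as from compound 1 to compound 2, but here the place is two bonds along the chain from an amine nitrogen and a saturated ring carbon rather than bound directly to a saturated ring carbon. Resting on the step of a 12-fold lower number from compound 1 to compound 2 (1.09 log units; beyond the scatter), compound 4 is expected to give 110 nM in this assay, between 40 nM and 320 nM, a step of a 5.5-fold lower number from compound 3 to compound 4 (0.74 log units; beyond the scatter) expected from compound 3.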

Compound 4, inhibition constant: 3450 nM
For compound 4 the middle estimate is 31-fold (1.50 log units) below the measured one, outside the stated range (above it).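

In this assay the new step is a 5.7-fold higher number from compound 3 to compound 4 (0.75 log units; beyond the scatter), so ethyl in place of hydrogen lowers the number on one core and raises it on the other. Set beside the earlier step, the change does not carry over between these cores: the same change on two cores in this assay, a 12-fold lower number (1.09 log units; beyond the scatter) from compound 1 to compound 2 and a 5.7-fold higher number (0.75 log units; beyond the scatter) from compound 3 to compound 4, 70-fold (1.84 log units) apart, beyond the scatter of two such steps. With a single pair on each core, this does not show which difference between the cores, or between the two places of the change, lies behind the reversal, nor does it give a rule for other compounds in the series.

As far as these compounds go, it remains open whether a longer chain such as butyl would follow the trend of the core of compound 1 or that of the core of compound 3. The same question stands for a cyclopropyl group at the same place.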